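This account rests on a few compounds, and the source may have more. Where it says the series, first, only, none or still open, it means among the compounds named here.

Measured so far in a functional assay on HCT-116 cells (Homo sapiens) for antiproliferative activity, read by MTT assay, with a stated time of 48 h; a higher number here means a weaker inhibitor, a lower number a stronger inhibitor:
Compound 1, `COc1cc(-c2nnc(SCC(=O)c3ccccc3)n2N)cc(OC)c1OC`, gives 53000 nM.
Compound 2, `COc1cc(-c2nnc(SCC(=O)c3ccc(Cl)cc3)n2N)cc(OC)c1OC`, gives 7500 nM.
Compound 3, `COc1cc(-c2nnc(SCC(=O)c3ccc(C)cc3)n2N)cc(OC)c1OC`, gives 370 nM.

All three share one core and differ only in a single group on the outer aromatic ring. Compound 3 stands lowest of the three numbers, that is, as the strongest inhibitor of this set: the step of a 20-fold lower number from compound 2 to compound 3 (1.31 log units; beyond the scatter) and the step of a 140-fold lower number from compound 1 to compound 3 (2.16 log units; beyond the scatter) are both beyond the scatter.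

Compound 4, `COc1cc(-c2nnc(SCC(=O)c3ccc(F)cc3)n2N)cc(OC)c1OC`, has not been measured. It differs from compound 3 as follows: fluoro in place of methyl on an aromatic carbon. Among the compounds with values here, two measured steps bear on this change. The step of a 20-fold lower number from compound 2 to compound 3 (1.31 log units; beyond the scatter) shows that swapping one heavy atom for methyl at this position helped strongly, and the step of a 140-fold lower number from compound 1 to compound 3 (2.16 log units; beyond the scatter) shows the same for hydrogen. Reversing the first of these suggests that removing the methyl in favour of another single heavy atom costs potency, so a rise in the number, beyond the scatter, is expected: a 22-fold higher number from compound 3 to compound 4 (1.33 log units; beyond the scatter). Compound 4 is therefore estimated at 8000 nM, with a range from 2000 nM to 40000 nM.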

Compound 4, half-maximal inhibitory concentration: 3230 nM
Compound 4: the middle estimate sits 2.5-fold (0.39 log units) above what was measured; the range from low to high includes it.
By their numbers in this assay, from the lowest: compound 3; then compound 4; then compound 2; then compound 1.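

In this assay, fluoro gives a third single-atom or single-carbon replacement at this place on the outer ring, and replacing methyl with it costs potency: an 8.7-fold higher number from compound 3 to compound 4 (0.94 log units; beyond the scatter) shows that methyl keeps its lead. Fluoro also improves on chloro, with a 2.3-fold lower number from compound 2 to compound 4 (0.37 log units; beyond the scatter) as the step, so the two halogens do not behave alike here, although both stay behind methyl. The step to fluoro from hydrogen, a 16-fold lower number from compound 1 to compound 4 (1.22 log units; beyond the scatter), means that all three groups shown beat hydrogen, with no compound here going against that, and nothing shown gives a reason for this order.

As far as these compounds go, whether an amine, a methoxy group or a longer chain such as ethyl at this place would match methyl stays open. So does whether the same order would hold with these groups on another carbon of this ring.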